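The source may report more compounds than this note shows. Statements on the series, on what has been measured and on what is new or still open speak of the compounds shown alone.

Measured in a functional assay on HT-29 cells (Homo sapiens) for inhibition, read by MTT assay, with a stated time of 72 h; a lower number here means a stronger inhibitor, a higher number a weaker inhibitor:
- compound 1 `COc1cccc(/C=C/C(=O)Nc2cc(OC)c(OC)c(OC)c2)c1`: 44100 nM
- compound 2 `C=C(Br)C(=O)Nc1cccc(/C=C/C(=O)Nc2cccc(F)c2)c1`: 4600 nM
- compound 3 `C=C(Br)C(=O)Nc1cccc(/C=C/C(=O)Nc2ccc(F)c(F)c2)c1`: 8700 nM

Compound 3, at 8700 nM, lies within the scatter of compound 2 and has a clearly lower number than compound 1. Compound 4 `C=C(Br)C(=O)Nc1cccc(/C=C/C(=O)Nc2ccc(OC)cc2)c1` carries 4-methoxyphenyl in place of 3,4-difluorophenyl on an amide-type nitrogen. Among the measured compounds shown here, only one measured step bears on this change: a 1.9-fold higher number from compound 2 to compound 3 (0.28 log units; within the scatter), with fluoro in place of hydrogen on an aromatic carbon. For the measured compounds named here, that is slim evidence, and no measured compound carries a methoxy group at this place. No step beyond the scatter is therefore expected, and the estimate amounts to a 1.5-fold lower number from compound 3 to compound 4 (0.16 log units; within the scatter). For compound 4 the estimated value is 6000 nM, with an expected range of 2000 nM to 18000 nM.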

Compound 4, half-maximal inhibitory concentration: 2300 nM
Beside the measured number, compound 4's estimate is 2.6-fold (0.42 log units) above it; low and high end bracket the measured number.
By their numbers in this assay, from the lowest: compounds 4, 2 and 3 (each within the scatter of the next, the first and the last beyond it); then compound 1.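

In this assay, among the compounds shown here, the earlier compounds showed only a fluoro change on this aromatic ring, and that change stayed within the scatter. Here, 4-methoxyphenyl in place of 3,4-difluorophenyl on the amide-type nitrogen gives a 3.8-fold lower number from compound 3 to compound 4 (0.58 log units; beyond the scatter), so a change at this place can exceed the scatter. In place of 3-fluorophenyl, the same group gives a 2.0-fold lower number from compound 2 to compound 4 (0.30 log units; within the scatter), which does not separate the two groups. Nothing available explains these steps.

As far as these compounds go, what an amine or a carboxylic acid would do at this place remains open, as does the result for an unsubstituted phenyl.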